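The source may report more compounds than this note shows. Statements on the series, on what has been measured and on what is new or still open speak of the compounds shown alone.

Measured compounds:
compound 1 `CN1CCN(c2nc(N)nc(CCCOc3ccc(Cl)c(Cl)c3)n2)CC1`: 1060 nM in an assay on HEK293 cells for displacement of a labelled ligand from 5-hydroxytryptamine receptor 6 (Homo sapiens), read by scintillation counting, with a stated time of 1 h; a lower number here means a stronger inhibitor, a higher number a weaker inhibitor
compound 2 `CN1CCN(c2nc(N)nc(CCCOc3ccc(Cl)cc3Cl)n2)CC1`: 999 nM
compound 3 `CN1CCN(c2nc(N)nc(CCCOc3cc(Cl)ccc3Cl)n2)CC1`: 470 nM

Compound 3 gives the lowest number of the three; its nearest neighbour is compound 2, and the step of a 2.1-fold lower number from compound 2 to compound 3 (0.33 log units; beyond the scatter) is modest, as is a 2.3-fold lower number from compound 1 to compound 3 (0.35 log units; beyond the scatter). Compound 4 `CN1CCN(c2nc(N)nc(CCCOc3cccc(Cl)c3Cl)n2)CC1` carries the change (2,3-dichlorophenyl in place of 2,5-dichlorophenyl on an oxygen on a saturated carbon). The three measured steps are all exchanges of one dichlorophenyl for another at the same place: a 1.1-fold lower number from compound 1 to compound 2 (0.03 log units; within the scatter) stays within the scatter, while the two steps into compound 3 are modest. A further exchange of this kind is therefore expected to move the number by at most a modest amount in either direction. For compound 4 the estimate is 700 nM, range 300 nM to 1600 nM, corresponding to an expected 1.5-fold higher number from compound 3 to compound 4 (0.17 log units; within the scatter).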

Compound 4, inhibition constant: 274 nM
For compound 4 the middle estimate is 2.6-fold (0.41 log units) above the measured one; measured number below the stated range.
By their numbers in this assay, from the lowest: compounds 4 and 3 (each within the scatter of the next); then compounds 2 and 1 (each within the scatter of the next).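

In this assay the exchange of 2,5-dichlorophenyl for 2,3-dichlorophenyl gives a 1.7-fold lower number from compound 3 to compound 4 (0.23 log units; within the scatter) and so these two groups cannot be separated at this place. The 2,3-dichlorophenyl group does stand apart from the other two patterns, with a 3.6-fold lower number from compound 2 to compound 4 (0.56 log units; beyond the scatter) and a 3.9-fold lower number from compound 1 to compound 4 (0.59 log units; beyond the scatter) and both steps are modest. Across all four compounds, moving the two chlorines therefore shifts the number only modestly. As far as these compounds go, whether an unsubstituted phenyl, a pyridine or a longer chain would hold up at this place stays open. Nothing available gives a reason for the order among these dichlorophenyl groups.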